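Swapping a thioether ring: from fluorine to two chlorines

The compounds below may be only part of what the source reports. "The series", "measured", "known", "first", "only" and "open" are said of these compounds alone.

Of the compounds shown here, three built on one shared core have been tested in a functional assay on MDA-MB-231 cells (Homo sapiens) for inhibition, read by sulforhodamine B assay, with a stated time of 48 h; on this read-out lower numbers stand for higher toxicity in this test and higher numbers for lower toxicity in this test. Compound 1 `Nc1cc(N)c2nc(-c3ccccc3)c(NCc3ccc(Cl)c(Cl)c3)nc2c1` gives only an assay limit, < 100000 nM, rather than a number; this is the limit of < 100000 nM in this assay, at which 1 of the 3 values shown sits. Among the measured compounds shown here, compound 2 `Nc1cc(N)c2nc(-c3ccccc3)c(Sc3ccc(F)cc3)nc2c1` gives 83200 nM, the highest of the two numbers known here. Compound 3 `COc1cc(CNc2nc3cc(N)cc(N)c3nc2-c2ccccc2)cc(OC)c1OC` gives 31600 nM, a lower number that lies beyond the usual scatter when set against compound 2.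

Compound 4 `Nc1cc(N)c2nc(-c3ccccc3)c(Sc3ccc(Cl)c(Cl)c3)nc2c1` has not yet been measured. It differs from compound 2 in a single place: 3,4-dichlorophenyl in place of 4-fluorophenyl on a sulfur. For the measured compounds named here, no pair of measured compounds shows exactly this kind of swap, so no measured step can be pointed to for guidance; the only comparison at hand, between compound 2 and compound 3, changes a different part of the molecule altogether.

Compound 4 is therefore expected to land somewhat lower than compound 2, by a step of a 1.5-fold lower number from compound 2 to compound 4 (0.18 log units; within the scatter), a shift that may well sit within the scatter. The estimate for compound 4 is 55000 nM, with a range from 20000 nM to 100000 nM.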

Compound 4, concentration lethal to 50% of the cells: < 100000 nM
Compound 4: no number, only a limit (the forecaster's own chance of this, stated with the estimate: 25%); the middle value is on the limit's open side.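

Compound 4 gives only a limit of the assay, < 100000 nM, rather than a number, so the step from compound 2 to compound 4 cannot be read. The compounds shown leave open whether 3,4-dichlorophenyl in place of 4-fluorophenyl on a sulfur changes the value in this assay, and in which direction.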